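The source may hold more compounds than are shown below. What is called first, only, known or untested is meant among the compounds shown, and "the series" means these compounds.

Measured in a functional assay on the whole organism (strain NMRI) with Mus musculus as the target, in the maximal electroshock model, with a stated time of 4 h; a lower number here means that less compound is needed, a higher number that more compound is needed for the effect:
Compound 1 `COc1ccc(Cn2cc(CO/N=C/c3c(-c4ccccc4)nc4c(C)cccn34)nn2)cc1` gives 40 mg/kg.
Compound 2 `C#CCO/N=C/c1c(-c2ccc(C)cc2)nc2ccc(Br)cn12` gives 20 mg/kg.
Compound 3 `Cc1ccc(-c2nc3ccc(Br)cn3c2/C=N/OCc2cn(Cc3ccc([N+](=O)[O-])cc3)nn2)cc1` gives 100 mg/kg.

Compound 3 stands highest of the three numbers; the nearest is compound 1, lower by more than the usual scatter, and the furthest is compound 2, also lower by more than the scatter. Compound 4 `O=[N+]([O-])c1ccc(Cn2cc(CO/N=C/c3c(-c4ccccc4)nc4ccc(Br)cn34)nn2)cc1` differs from compound 3 by hydrogen in place of methyl on an aromatic carbon, which cut one bond further out reads 4-methylphenyl to phenyl. Going by the values given here, no two measured compounds differ in one place only, so no such step is on record; compound 1, which also carries phenyl but differs from compound 3 elsewhere, gives the lower number. In this assay a small step toward a lower number is expected, perhaps not beyond the scatter. For compound 4 the estimate is 70 mg/kg, range 30 mg/kg to 160 mg/kg, an expected step of a 1.4-fold lower number from compound 3 to compound 4 (0.15 log units; within the scatter).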

Compound 4, minimum effective dose: 40 mg/kg
Compound 4: the middle estimate sits 1.8-fold (0.24 log units) above what was measured, within the range that was stated.
By their numbers in this assay, from the lowest: compounds 2, 1 and 4 (each within the scatter of the next); then compound 3.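

In this assay, going by these compounds alone, the change from 4-methylphenyl to phenyl gives a 2.5-fold lower number from compound 3 to compound 4 (0.40 log units; beyond the scatter), the first step that differs in one place only. It shows that this aromatic carbon, para to a large group, is sensitive to substitution, and that on this background the methyl is not needed for the effect. Nothing on hand explains the size of the step.

Still open, going by these compounds, is whether the same step holds with the side chain of compound 2. Also open, on these data alone, is how a methoxy group or an amine at this place would compare with methyl and hydrogen.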